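The source may report more compounds than this note shows. Statements on the series, on what has been measured and on what is new or still open speak of the compounds shown alone.

The shared core of compound 1 `CCCOc1ccc(C(=O)Nc2cccc(CC)n2)cc1` carries an ethyl group, and in an in vitro assay on HEK-tsA201 cells for antagonist activity at Neuronal acetylcholine receptor; alpha4/beta2 (Homo sapiens), read by fluorescence and calcium flux (on this read-out higher numbers stand for weaker inhibition and lower numbers for stronger inhibition), compound 1 gives 37600 nM. Compound 2 `CCCOc1ccc(C(=O)Nc2cccc(Nc3ccc(F)cc3)n2)cc1` reaches only a limit of this assay, > 100000 nM. Compound 3 `CCCOc1ccc(C(=O)Nc2cccc(Nc3ccc(Cl)cc3)n2)cc1` likewise sits at a limit of this assay, > 100000 nM. The steps of an at least 2.6-fold higher number from compound 1 to compound 2 (0.42 log units; beyond the scatter) and an at least 2.6-fold higher number from compound 1 to compound 3 (0.42 log units; beyond the scatter) are thus read against (the limit of > 100000 nM in this assay, at which 2 of the 3 values shown sit), and the step that the two limits leave unreadable from compound 2 to compound 3 cannot be sized. Compound 4 `CCCOc1ccc(C(=O)Nc2cccc(N3CCCCC3)n2)cc1` is not yet measured; it differs from compound 3 by piperidin-1-yl in place of (4-chlorophenyl)amino on an aromatic carbon. Among the measured compounds shown here, no measured step exchanges an arylamino for a saturated ring, so the expectation leans on compound 1, which gives 37600 nM. Compound 4 is therefore expected near 60000 nM, within 15000 nM to 200000 nM. That expected step an at least 1.6-fold lower number from compound 3 to compound 4 (0.22 log units; that floor lies within the scatter) carries a real chance that compound 4 again returns only a limit.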

Compound 4, half-maximal inhibitory concentration: > 100000 nM
Compound 4: a limit, no number; the forecaster's own chance of this, stated with the estimate: 45%; middle value at least 1.6-fold (0.22 log units) from the limit.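

Piperidin-1-yl, a saturated ring with no hydrogen-bond donor, gives an at least 2.6-fold higher number from compound 1 to compound 4 (0.42 log units; beyond the scatter) in this assay, so at this position the loss against ethyl is not confined to the two arylamino groups. The amino hydrogen that those groups carry is thus not required for the change to appear. The steps among compound 2, compound 3 and compound 4 cannot be read, as all three return only a limit: the limit of > 100000 nM in this assay, at which 3 of the 4 values shown sit.

Left open is whether a methyl or a dimethylamino group here would return a number rather than a limit. On these data alone, it also remains unknown whether any group at this position improves on ethyl.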